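Trifluoromethyl on the benzyl arm of the cyclopentylamine

The source may report more compounds than this note shows. Statements on the series, on what has been measured and on what is new or still open speak of the compounds shown alone.

Three compounds share one core and differ at two places, the amine substituent and the benzyl arm. Compound 1 `CCCCNc1nc(-c2ccccc2)nc2c1nnn2Cc1ccccc1C(F)(F)F` carries a butylamino group and a benzyl bearing trifluoromethyl; in an assay on Cerebral cortex for displacement of a labelled ligand from adenosine receptor A1 (Bos taurus) (a lower number here means a stronger inhibitor, a higher number a weaker inhibitor), compound 1 gives 6.5 nM. Compound 2 `CCCCCCNc1nc(-c2ccccc2)nc2c1nnn2Cc1ccccc1C(F)(F)F` is the hexylamino analogue of compound 1. In this assay compound 2 has no number: the result is recorded as "not determined" (no result reported). Compound 3 `c1ccc(Cn2nnc3c(NC4CCCC4)nc(-c4ccccc4)nc32)cc1` pairs a cyclopentylamino group with an unsubstituted benzyl; in this assay compound 3 gives 11 nM. Within the data shown here, the two numbers available, for compound 1 and compound 3, lie within the usual scatter of each other, so the series so far shows no separation between them.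

Compound 4 `FC(F)(F)c1ccccc1Cn1nnc2c(NC3CCCC3)nc(-c3ccccc3)nc21` is compound 3 with one change: trifluoromethyl in place of hydrogen on an aromatic carbon. Among the measured compounds shown here, no directly comparable pair has been measured, since compound 1 and compound 3 differ at two places at once. With the two known values sitting so close, the step from compound 3 to compound 4 is expected to be small, with a slight lean toward a lower number, a 1.8-fold lower number from compound 3 to compound 4 (0.26 log units; within the scatter), because compound 1, which already carries the trifluoromethylbenzyl, gives 6.5 nM. For compound 4 the expected value in this assay is 6 nM, within a range of 2.5 nM to 15 nM.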

Compound 4, inhibition constant: 0.6 nM
Beside the measured number, compound 4's estimate is 10-fold (1.00 log units) above it; the whole stated range lies above it.
By their numbers in this assay, from the lowest: compound 4; then compounds 1 and 3 (each within the scatter of the next).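

The trifluoromethyl group on this benzyl arm is not the small change that the earlier numbers suggested: on an aromatic carbon, ortho to a large group, with cyclopentylamino held fixed, this assay shows an 18-fold lower number from compound 3 to compound 4 (1.26 log units; beyond the scatter) for trifluoromethyl in place of hydrogen. With the trifluoromethylbenzyl arm held fixed, the amine substituent also matters, as cyclopentyl in place of butyl on the nitrogen gives an 11-fold lower number from compound 1 to compound 4 (1.03 log units; beyond the scatter). The closeness of the values for compound 1 and compound 3 therefore says little about either change alone, and nothing available here explains why either step is so large.

Going by these compounds, whether a chlorine, a methyl or a methoxy group in the same place would give a step of similar size remains open, and so does whether trifluoromethyl gives the same step when the amine carries butyl rather than cyclopentyl. Also open, on these data alone, is how far the cyclopentyl step depends on the trifluoromethyl group, and whether a cyclohexyl ring or a branched chain such as isopropyl on the nitrogen would match cyclopentyl.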